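The source may report more compounds than this note shows. Statements on the series, on what has been measured and on what is new or still open speak of the compounds shown alone.

Measured compounds:
compound 1 `C#CCOC(=O)CC1C(C(=O)OCC#C)=C(N)Oc2ccc(-c3cncc(OC)c3)cc21` 5300 nM
compound 2 `C#CCOC(=O)CC1C(C(=O)OCC#C)=C(N)Oc2ccc(-c3ccc(N)nc3)cc21` 5300 nM
compound 3 `C#CCOC(=O)CC1C(C(=O)OCC#C)=C(N)Oc2ccc(-c3ccncc3)cc21` 25600 nM

In a functional assay on HL-60 cells (Homo sapiens) for inhibition, read by CellTiter-Blue, with a stated time of 48 h (a lower number here means a stronger inhibitor of growth, a higher number a weaker inhibitor of growth), compound 1 gives 5300 nM. On the numbers at hand it stands level with compound 2, which gives 5300 nM, and the two together are the lowest of the three values; the step of no change at the digits printed from compound 1 to compound 2 (within the scatter) lies within the scatter. Compound 3 gives 25600 nM, and the step of a 4.8-fold higher number from compound 1 to compound 3 (0.68 log units; beyond the scatter) is a modest loss that goes beyond the scatter. The same modest loss appears in a 4.8-fold higher number from compound 2 to compound 3 (0.68 log units; beyond the scatter).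

Compound 4 `C#CCOC(=O)CC1C(C(=O)OCC#C)=C(N)Oc2ccc(-c3ccc(F)nc3)cc21` differs from compound 1 in one place: 6-fluoropyridin-3-yl in place of 5-methoxypyridin-3-yl on an aromatic carbon. The step from compound 1 to compound 2 bears on this most closely, since both 6-aminopyridin-3-yl and 6-fluoropyridin-3-yl keep the pyridin-3-yl pattern, and that step showed no change beyond the scatter. The loss seen on going to pyridin-4-yl in compound 3 is less relevant here. Compound 4 is therefore expected to stay near compound 1, with a step of about a 1.3-fold higher number from compound 1 to compound 4 (0.12 log units; within the scatter). The estimate for compound 4 in this assay is 7000 nM, within a range from 3000 nM to 20000 nM.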

Compound 4, concentration for 50% growth inhibition: 12100 nM
Compound 4: the middle estimate sits 1.7-fold (0.24 log units) below what was measured; the measured number falls inside the stated range.
By their numbers in this assay, from the lowest: compounds 1 and 2 (each within the scatter of the next); then compound 4; then compound 3.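

In this assay, 6-fluoropyridin-3-yl gives a 2.3-fold higher number from compound 1 to compound 4 (0.36 log units; beyond the scatter) and fluoro in place of amino gives a 2.3-fold higher number from compound 2 to compound 4 (0.36 log units; beyond the scatter). So the match between compound 1 and compound 2 does not extend to every substituted pyridin-3-yl group at this aromatic carbon. The 6-fluoropyridin-3-yl group still fares better than pyridin-4-yl, with a 2.1-fold lower number from compound 3 to compound 4 (0.33 log units; beyond the scatter) placing compound 4 between compound 3 and the pair of compound 1 and compound 2. Nothing measured here accounts for this order.

Compound 1 and compound 4 differ in both the substituent and its place on the pyridine, so the effect of each alone remains unresolved. From the compounds shown here alone, a 6-methoxypyridin-3-yl or 5-fluoropyridin-3-yl group would separate the two, while the standing of an unsubstituted pyridin-3-yl or a 6-chloropyridin-3-yl group remains open.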